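A few compounds are considered here, and "the series" means these few. Any claim that something is new, unique, unknown or untested is made for them only; others in the source may bear on it.

Measured so far in a functional assay on the whole organism with Rattus norvegicus as the target (a lower number here means that less compound is needed, a higher number that more compound is needed for the effect), as doses:
- compound 1 (`CCN(CCNC(=O)c1cc(Cl)c(N)cc1OC)Cc1ccoc1`): 3 mg/kg
- compound 2 (`CCN(CCNC(=O)c1cc(Cl)c(N)cc1OC)Cc1cccc(Cl)c1`): 0.58 mg/kg

Within the data shown here, of these two, compound 2 has the lower number at 0.58 mg/kg and compound 1 is its only neighbour. The next compound, compound 3 (`CCN(CCNC(=O)c1cc(Cl)c(N)cc1OC)Cc1ccc(F)cc1`), differs from compound 2 by 4-fluorophenyl in place of 3-chlorophenyl on a saturated chain carbon bound to an amine nitrogen and so carries 4-fluorophenyl in place of 3-chlorophenyl on a saturated chain carbon bound to an amine nitrogen. Among the measured compounds shown here, the only measured step at this place is a 5.2-fold lower number from compound 1 to compound 2 (0.71 log units; beyond the scatter) on going from furan-3-yl to 3-chlorophenyl. For the measured compounds named here, that step bears only indirectly, since no measured pair exchanges one substituted phenyl for another. No step beyond the scatter is therefore expected, with a slight lean towards a higher number. The expected change is a 1.7-fold higher number from compound 2 to compound 3 (0.24 log units; within the scatter) in this estimate. An estimate puts compound 3 at 1 mg/kg (range 0.35 mg/kg to 3 mg/kg).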

Compound 3, dose for half-maximal effect: 0.2 mg/kg
Compound 3: middle estimate off by 5.0-fold (0.70 log units), on the high side; the whole stated range lies above it.
By their numbers in this assay, from the lowest: compound 3; then compound 2; then compound 1.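

In this assay, the exchange of one substituted phenyl for another on a saturated chain carbon bound to an amine nitrogen gives (a 2.9-fold lower number from compound 2 to compound 3 (0.46 log units; beyond the scatter)), so this place responds to more than the earlier swap of furan-3-yl for a phenyl group. Measured against the furan-3-yl compound, 4-fluorophenyl gives a larger step than 3-chlorophenyl did, and this wider comparison is (a 15-fold lower number from compound 1 to compound 3 (1.18 log units; beyond the scatter)). Nothing measured here explains either step.

The change from 3-chlorophenyl to 4-fluorophenyl alters both the halogen and its place on the ring, and the compounds shown do not separate the two. Neither 4-chlorophenyl nor 3-fluorophenyl is among them, and unsubstituted phenyl, which would show what either halogen contributes, is also absent.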